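The compounds below may be only part of what the source reports. "The series", "measured", "known", "first", "only" and "open" are said of these compounds alone.

Measured so far:
compound 1 `CC1CCN(C2CCN(S(=O)(=O)c3ccccc3-c3ccc(C(F)(F)F)cc3)CC2)CC1` — 122 nM
compound 2 `CC1CCN(C2CCN(S(=O)(=O)c3ccccc3-c3ccc(Cl)cc3)CC2)CC1` — 202 nM
compound 3 `CC1CCN(C2CCN(S(=O)(=O)c3ccc(Cl)c(C(F)(F)F)c3)CC2)CC1` — 17 nM

In a functional assay on DLD-1 cells (Homo sapiens) for antiproliferative activity, read by CellTiter-Glo, with a stated time of 72 h (on this read-out higher numbers stand for weaker inhibition and lower numbers for stronger inhibition), compound 3 gives the lowest number of the three; compound 1 and compound 2 stand within the scatter of each other, as a 1.7-fold higher number from compound 1 to compound 2 (0.22 log units; within the scatter) shows. The difference between the core of compound 3 and the core of compound 1 is not broken down here.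

Compound 4 `CC1CCN(C2CCN(S(=O)(=O)c3ccc(Cl)c(Cl)c3)CC2)CC1` is not yet measured. Its change from compound 3, (chloro in place of trifluoromethyl on an aromatic carbon), is the same kind of change as that from compound 1 to compound 2, (chloro in place of trifluoromethyl on an aromatic carbon), but the place differs: in compound 1 the group sits para to a large group, in compound 3 ortho to a chloro group and meta to a large group.

From compound 3 to compound 4 a step of about a 1.5-fold higher number from compound 3 to compound 4 (0.18 log units; within the scatter) is expected, resting on compound 1 and a 1.7-fold higher number from compound 1 to compound 2 (0.22 log units; within the scatter). For compound 4 the estimate is 26 nM, between 10 nM and 65 nM.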

Compound 4, half-maximal inhibitory concentration: 2.9 nM
Beside the measured number, compound 4's estimate is 9.0-fold (0.95 log units) above it; measured number below the stated range.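

In this assay, chloro in place of trifluoromethyl gives a 5.9-fold lower number from compound 3 to compound 4 (0.77 log units; beyond the scatter), so the step seen on the core of compound 1 cannot be carried over to the core of compound 3 as a fixed increment. The two steps differ: the same change on two cores in this assay, a 1.7-fold higher number (0.22 log units; within the scatter) from compound 1 to compound 2 and a 5.9-fold lower number (0.77 log units; beyond the scatter) from compound 3 to compound 4, 9.7-fold (0.99 log units) apart, beyond the scatter of two such steps

Two pairs alone do not separate the place of the group from the rest of the core, and they give no reason for the gap between the steps.

Still open, on these data alone, is how a nitrile, an amine or a methoxy group at this place would compare with the chloro group of compound 4. Also open, as far as these compounds go, is whether a carboxylic acid or a longer chain on this aromatic ring would be tolerated.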